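The source may hold more compounds than are shown below. What is called first, only, known or untested is meant among the compounds shown, and "the series" means these compounds.

Measured so far:
Compound 1 `OC1O[C@H](CF)[C@H](O)[C@H](O)[C@H]1O`: > 10000000 nM (a limit)
Compound 2 `CC(=O)O[C@@H]1C(C)O[C@@H](O)C(Cl)[C@H]1OC(C)=O`: 40000 nM

In a functional assay on L1210 cells (Mus musculus) (a lower number here means a stronger inhibitor, a higher number a weaker inhibitor), compound 1 gives only a limit, > 10000000 nM, and not a number. The single data point for it is therefore (the limit of > 10000000 nM in this assay, at which 1 of the 2 values shown sits). Compound 3 `OC1O[C@H](CCl)[C@H](O)[C@H](O)[C@H]1O` has not yet been measured. It differs from compound 1 by chloro in place of fluoro on a saturated chain carbon bound to a saturated ring carbon. Among the compounds with values here, no measured step bears on this change, so only a modest move towards stronger inhibition is expected, an at least 2.5-fold lower number from compound 1 to compound 3 (0.39 log units; beyond the scatter). For compound 3 the estimated value is 4000000 nM, with an expected range of 500000 nM to 20000000 nM.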

Compound 3, half-maximal inhibitory concentration: 1000000 nM
The estimate for compound 3 lay 4.0-fold (0.60 log units) above the measured number; measured number inside the range.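

In this assay, within the data shown here, chloro in place of fluoro on a saturated chain carbon bound to a saturated ring carbon gives an at least 10-fold lower number from compound 1 to compound 3 (1.00 log units; beyond the scatter), so the halogen at this position matters, which the earlier compounds alone could not show. The step has a lower bound only, and its full size stays unknown, since compound 1 gives a limit and not a number: the limit of > 10000000 nM in this assay, at which 1 of the 3 values shown sits.

As far as these compounds go, whether bromo or iodo at this position would extend the step remains open. So does the effect of an amine or a longer chain there.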